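A few compounds are considered here, and "the series" means these few. Any claim that something is new, unique, unknown or untested is made for them only; others in the source may bear on it.

Among the compounds with values here, in a functional assay on MKN-45 cells (Homo sapiens) for antiproliferative activity, read by CellTiter-Glo, with a stated time of 3 days (a higher number here means a weaker inhibitor, a lower number a stronger inhibitor), compound 1 `CC(Oc1c(N)ncc2c(-c3cnn(C4CCNCC4)c3)coc12)c1cc(F)ccc1Cl` gives 6400 nM, the higher of the two numbers so far, while compound 2 `CC(Oc1c(N)ncc2c(-c3cnn(C4CCNCC4)c3)coc12)c1c(Cl)c(F)cc(F)c1Cl` gives 480 nM. Compound 3 `CC(Oc1c(N)ncc2c(-c3cnn(C4CCNCC4)c3)coc12)c1c(Cl)cc(Cl)cc1Cl` is still unmeasured. Its difference from compound 1 is 2,4,6-trichlorophenyl in place of 2-chloro-5-fluorophenyl on a saturated chain carbon bound to an oxygen on an aromatic ring and a saturated chain carbon. Within the data shown here, only one measured step bears on this change: a 13-fold lower number from compound 1 to compound 2 (1.12 log units; beyond the scatter), a large step at the same place, also to a larger halogenated phenyl group. A single step supports the direction better than the size, so a lower number in this assay is expected, though probably by a smaller step. The expected change is a 5.8-fold lower number from compound 1 to compound 3 (0.76 log units; beyond the scatter). The estimate for compound 3 is 1100 nM, with an expected range of 300 nM to 4000 nM.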

Compound 3, half-maximal inhibitory concentration: 3600 nM
Compound 3: middle estimate off by 3.3-fold (0.51 log units), on the low side; low and high end bracket the measured number.
By their numbers in this assay, from the lowest: compound 2; then compounds 3 and 1 (each within the scatter of the next).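

In this assay, a larger halogenated phenyl group on this saturated chain carbon does not by itself bring a lower number: 2,4,6-trichlorophenyl in place of 2-chloro-5-fluorophenyl gives only a change within the scatter (a 1.8-fold lower number from compound 1 to compound 3 (0.25 log units; within the scatter)). The group of compound 2 remains clearly ahead of 2,4,6-trichlorophenyl (a 7.5-fold higher number from compound 2 to compound 3 (0.88 log units; beyond the scatter)), so across these three compounds the count of halogens on the phenyl group does not track the number, and the identity and pattern of the halogens matter here. Nothing at hand accounts for the difference between these phenyl groups.

Which single feature of the group of compound 2 carries its lower number stays open. So does the outcome at this place for a phenyl group bearing methoxy or an amine instead of halogens.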